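Phenyl for thiophen-3-yl on the shared core

This account rests on a few compounds, and the source may have more. Where it says the series, first, only, none or still open, it means among the compounds named here.

Compound 1 `Nc1nc(N)c2c(-c3ccoc3)cn([C@@H]3O[C@H](CO)[C@@H](O)[C@H]3O)c2n1` and compound 2 `Cc1nc(N)c2c(-c3ccsc3)cn([C@@H]3O[C@H](CO)[C@@H](O)[C@H]3O)c2n1` have both been run in a functional assay on CCRF-CEM cells (Homo sapiens), read by MTT assay, with a stated time of 72 h; a lower number here means a stronger inhibitor, a higher number a weaker inhibitor. For compound 1 the result is only a limit, > 20000 nM. For compound 2 the result is likewise a limit, > 20000 nM. Among the measured compounds shown here, compound 2 thus stands at the limit of > 20000 nM in this assay, at which 2 of the 2 values shown sit; no step between measured compounds is available. Compound 3 `Cc1nc(N)c2c(-c3ccccc3)cn([C@@H]3O[C@H](CO)[C@@H](O)[C@H]3O)c2n1` differs from compound 2 by phenyl in place of thiophen-3-yl on an aromatic carbon. With compound 2 at a limit, no direction can be read from the numbers shown; the expected step is none beyond the scatter, a step that the limit leaves unreadable from compound 2 to compound 3. Compound 3 is expected to give 30000 nM in this assay, within 8000 nM to 100000 nM, most probably again reported only as a limit.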

Compound 3, half-maximal inhibitory concentration: > 20000 nM
Compound 3 was reported as a limit; the forecaster's own chance of this, stated with the estimate: 85%; the middle value does not contradict the limit.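

In this assay compound 3 gives > 20000 nM, a limit. Among the compounds shown here, compound 2 also stands at a limit, so no step to compound 3 can be read. The compounds shown leave open which group on the shared core, if any, would give a numerical value in this assay.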